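The source may hold more compounds than are shown below. What is called first, only, known or untested is meant among the compounds shown, and "the series" means these compounds.

Compounds measured in a functional assay on HT-29 cells (Homo sapiens) for cytotoxicity, read by MTT assay, with a stated time of 72 h; on this read-out higher numbers stand for weaker inhibition and lower numbers for stronger inhibition:
compound 1 `O=C(Nc1ccc(-n2ncc3c(Br)cccc32)cc1)Nc1ccc(Cl)c(C(F)(F)F)c1`: 4000 nM
compound 2 `O=C(Nc1ccc(-n2ncc3c(F)cccc32)cc1)Nc1ccc(Cl)c(C(F)(F)F)c1`: 8200 nM

Within the data shown here, of these two numbers, compound 2 holds the higher one, and the single change separating it from compound 1 was a 2.1-fold higher number from compound 1 to compound 2 (0.31 log units; beyond the scatter). Compound 3 `Cc1cccc2c1cnn2-c1ccc(NC(=O)Nc2ccc(Cl)c(C(F)(F)F)c2)cc1` is not yet measured; it differs from compound 2 in one place, (methyl in place of fluoro on an aromatic carbon). Among the measured compounds shown here, only the step from compound 1 to compound 2 bears on this change, since it concerns the same position of the shared core and also swapped one small group for another there. That step was modest but beyond the scatter, with the bromo compound giving the lower number. On this basis the change to methyl is expected to move compound 3 back toward the number of compound 1, a step of about a 1.8-fold lower number from compound 2 to compound 3 (0.26 log units; within the scatter) in this assay. Compound 3 is therefore estimated at 4500 nM, within a range from 2000 nM to 10000 nM.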

Compound 3, half-maximal inhibitory concentration: 32000 nM
Compound 3: the middle estimate sits 7.1-fold (0.85 log units) below what was measured, outside the stated range (above it).
By their numbers in this assay, from the lowest: compound 1; then compound 2; then compound 3.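

In this assay, methyl on this aromatic carbon of the shared core did not behave like the two halogens: methyl in place of fluoro gave a 3.9-fold higher number from compound 2 to compound 3 (0.59 log units; beyond the scatter), and methyl in place of bromo gave an 8.0-fold higher number from compound 1 to compound 3 (0.90 log units; beyond the scatter). Compound 3 therefore holds the highest number of the three, and exchanging one heavy atom for another, with no hydrogen-bond donor, acceptor or charge counted on either side, was enough to shift the number beyond the scatter. No measurement offered here accounts for this difference.

As far as these compounds go, it remains open whether chloro, an amine or methoxy at this position would give a number nearer that of compound 1 or compound 3. From the compounds shown here alone, whether bromo, fluoro and methyl would keep this order on other cells also remains open.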